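Swapping the aryl group on the shared core: the next step

This account rests on a few compounds, and the source may have more. Where it says the series, first, only, none or still open, it means among the compounds named here.

Two compounds share one core and differ only in the aryl group on a saturated ring carbon. Compound 1 `CCOC(=O)C1=C(C[Se]C(=O)c2ccc(C)cc2)NC(=O)NC1c1ccc(N(C)C)cc1` gives 29600 nM in a physicochemical assay, read by spectrophotometry, with a stated time of 10 min (on this read-out lower numbers stand for an effect already at smaller amounts and higher numbers for an effect only at larger amounts of compound), and compound 2 `CCOC(=O)C1=C(C[Se]C(=O)c2ccc(C)cc2)NC(=O)NC1c1ccc(O)c(OC)c1` gives 8100 nM, the lowest of the two numbers. Among the compounds with values here, the one measured step, a 3.7-fold lower number from compound 1 to compound 2 (0.56 log units; beyond the scatter), shows this aryl group matters. Compound 3 `CCOC(=O)C1=C(C[Se]C(=O)c2ccc(C)cc2)NC(=O)NC1c1ccc(C)cc1` carries 4-methylphenyl in place of 4-hydroxy-3-methoxyphenyl on a saturated ring carbon. That step bears on it only indirectly, so a modest rise back toward compound 1 is expected, a 3.1-fold higher number from compound 2 to compound 3 (0.49 log units; beyond the scatter). Compound 3 is therefore estimated at 25000 nM, within 8000 nM to 80000 nM.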

Compound 3, half-maximal effective concentration: 21200 nM
Compound 3: middle estimate off by 1.2-fold (0.07 log units), on the high side; measured number inside the range.
By their numbers in this assay, from the lowest: compound 2; then compounds 3 and 1 (each within the scatter of the next).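

In this assay the lower number of compound 2 now stands out against two different groups: 4-methylphenyl in place of 4-hydroxy-3-methoxyphenyl also gives a higher number (a 2.6-fold higher number from compound 2 to compound 3 (0.42 log units; beyond the scatter)). Methyl in place of dimethylamino on the aromatic carbon stays within the scatter (a 1.4-fold lower number from compound 1 to compound 3 (0.14 log units; within the scatter)), so compound 1 and compound 3 cannot be told apart. Nothing available here explains the difference seen with compound 2.

Still open, as far as these compounds go, is whether the hydroxy or the methoxy group alone accounts for the lower number of compound 2, as 4-hydroxyphenyl or 3-methoxyphenyl would show. From the compounds shown here alone, how a carboxylic acid on this aromatic ring would read also remains unknown.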